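Compound 4: bromo for chloro on the 4-chlorophenyl ring

The source may report more compounds than this note shows. Statements on the series, on what has been measured and on what is new or still open speak of the compounds shown alone.

Compound 1 `N#CC1=C(N)N(c2ccc(S(N)(=O)=O)cc2)C2=C(C(=O)CCC2)C1c1ccc(Cl)cc1Cl` gives 25 ug/mL in a functional assay on Ehrlich cells (Mus musculus) for cytotoxicity, read by trypan blue exclusion, with a stated time of 2 h; a lower number here means a stronger inhibitor, a higher number a weaker inhibitor. Compound 2 `N#CC1=C(NC(=S)Nc2ccccc2)N(c2ccc(S(N)(=O)=O)cc2)C2=C(C(=O)CCC2)C1c1ccc(Cl)cc1Cl` gives 25 ug/mL in this assay, and compound 3 `N#CC1=C(NC(=S)Nc2ccc(Cl)cc2)N(c2ccc(S(N)(=O)=O)cc2)C2=C(C(=O)CCC2)C1c1ccc(Cl)cc1Cl` gives 40 ug/mL. Compound 3 carries the highest of the three numbers, yet its gaps to compound 1 and to compound 2 both lie within the scatter, so no order among the three can be read. Compound 4 `N#CC1=C(NC(=S)Nc2ccc(Br)cc2)N(c2ccc(S(N)(=O)=O)cc2)C2=C(C(=O)CCC2)C1c1ccc(Cl)cc1Cl` differs from compound 3 by bromo in place of chloro on an aromatic carbon. Among the compounds with values here, no measured step exchanges one halogen for another; the nearest is a 1.6-fold higher number from compound 2 to compound 3 (0.20 log units; within the scatter), and no change at the digits printed from compound 1 to compound 2 (within the scatter) as well as a 1.6-fold higher number from compound 1 to compound 3 (0.20 log units; within the scatter) also stayed within the scatter. The expected step in this assay is no change at the digits printed from compound 3 to compound 4 (within the scatter), nothing beyond the scatter. Compound 4 is estimated at 40 ug/mL, with a range of 20 ug/mL to 80 ug/mL.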

Compound 4, half-maximal inhibitory concentration: 25 ug/mL
The estimate for compound 4 lay 1.6-fold (0.20 log units) above the measured number, within the range that was stated.
By their numbers in this assay, from the lowest: compounds 1, 2, 4 and 3 (each within the scatter of the next).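

In this assay, exchanging one halogen for another on the 4-chlorophenyl ring gives a 1.6-fold lower number from compound 3 to compound 4 (0.20 log units; within the scatter) and stays inside the noise of the series. Bromo in place of hydrogen on the same carbon gives no change at the digits printed from compound 2 to compound 4 (within the scatter) as its step, and the full 4-bromophenyl-bearing group on the amine nitrogen gives no change at the digits printed from compound 1 to compound 4 (within the scatter) as its step, so neither halogen at this position separates from the unsubstituted phenyl compound or the free amine. No supporting measurement bears on these small steps.

As far as these compounds go, whether a methoxy, nitro or carboxylic acid group on this ring carbon would step beyond the scatter remains open.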